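Aryl swap at the saturated ring carbon: thiophene variant

The compounds below may be only part of what the source reports. "The series", "measured", "known", "first", "only" and "open" are said of these compounds alone.

Measured compounds:
compound 1 `CN1C(=O)C(c2cccc(Cl)c2)N(C)c2nc(Nc3ccc(S(N)(=O)=O)cc3)ncc21`, 989 nM
compound 2 `CCc1ccccc1C1C(=O)N(C)c2cnc(Nc3ccc(S(N)(=O)=O)cc3)nc2N1C`, 51 nM

In an assay on Sf9 cells for inhibition of serine/threonine-protein kinase 4 (Homo sapiens), read by luminescence and ADP-Glo, with a stated time of 1 h, in the presence of a further agent that is not named here (on this read-out lower numbers stand for stronger inhibition and higher numbers for weaker inhibition), compound 1 gives 989 nM and compound 2 gives 51 nM. Among the measured compounds shown here, compound 2 holds the lowest number of the two, with compound 1 as its only neighbour, and the single step available is a 19-fold lower number from compound 1 to compound 2 (1.29 log units; beyond the scatter).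

Compound 3 `CN1C(=O)C(c2cccs2)N(C)c2nc(Nc3ccc(S(N)(=O)=O)cc3)ncc21` has not yet been measured. Relative to compound 2 the change is thiophen-2-yl in place of 2-ethylphenyl on a saturated ring carbon. For the measured compounds named here, the one step that bears on this position is the aryl exchange from compound 1 to compound 2, which was large, so the group on this saturated ring carbon clearly matters. Going by the values given here, no measured compound carries a five-membered ring here, so the direction rests on the observation that the small aryl of compound 1 gave 989 nM and the ethyl-bearing phenyl of compound 2 gave 51 nM.

For compound 3 the expected step is a 5.9-fold higher number from compound 2 to compound 3 (0.77 log units; beyond the scatter), a rise in the number. The estimate for compound 3 is 300 nM, with a range from 80 nM to 1200 nM.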

Compound 3, half-maximal inhibitory concentration: 88 nM
Compound 3: the middle estimate sits 3.4-fold (0.53 log units) above what was measured, within the range that was stated.
By their numbers in this assay, from the lowest: compounds 2 and 3 (each within the scatter of the next); then compound 1.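

In this assay, a five-membered aromatic ring is accepted on the saturated ring carbon: thiophen-2-yl in place of 2-ethylphenyl gives a step within the scatter (a 1.7-fold higher number from compound 2 to compound 3 (0.24 log units; within the scatter)), although the entering group has fewer heavy atoms and carries a sulfur. The large difference from compound 1 therefore does not depend on the 2-ethylphenyl group, since thiophen-2-yl in place of 3-chlorophenyl also gives a step beyond the scatter (an 11-fold lower number from compound 1 to compound 3 (1.05 log units; beyond the scatter)). No measured evidence explains why these groups differ in this way.

The compounds shown carry only aromatic rings at this carbon, so it remains open whether a ring such as cyclohexyl or a chain ending in an amine would fit there. Also open, on these data alone, is whether the 3-chlorophenyl result reflects the chlorine itself or its place on the phenyl ring.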